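Naphthyl trimethoxyphenyl methyl ethers: notes toward compound 4

The source may report more compounds than this note shows. Statements on the series, on what has been measured and on what is new or still open speak of the compounds shown alone.

Measured so far in a functional assay on HCT-116 cells (Homo sapiens) for inhibition, read by sulforhodamine B assay, with a stated time of 48 h; on this read-out lower numbers stand for stronger inhibition and higher numbers for weaker inhibition:
compound 1 `COc1cc(COC(c2ccc(OC)c(OC)c2OC)c2cccc3ccccc23)cc(OC)c1`: > 20000 nM, a limit of the assay
compound 2 `C=CCOC(c1ccc(OC)c(OC)c1OC)c1cccc2ccccc12`: > 20000 nM, a limit of the assay
compound 3 `COc1ccc(C(OCc2ccc(C)cc2)c2cccc3ccccc23)c(OC)c1OC`: > 20000 nM, a limit of the assay

Compound 3 stands on no number at all in this assay, only on the limit just given. The same holds for compound 1 and compound 2, as the limit of > 20000 nM in this assay, at which 3 of the 3 values shown sit, states. The three compounds differ from one another in the group on the saturated chain carbon bound to the ether oxygen, yet none of the steps between them can be read: a step that the two limits leave unreadable from compound 1 to compound 2, a step that the two limits leave unreadable from compound 1 to compound 3 and a step that the two limits leave unreadable from compound 2 to compound 3 all stay unreadable between two limits.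

Compound 4 `COC(=O)c1ccc(COC(c2ccc(OC)c(OC)c2OC)c2cccc3ccccc23)cc1` is the next member, not yet measured in this assay. Compared with compound 3 the change is methoxycarbonyl in place of methyl on an aromatic carbon. For the measured compounds named here, no measured step bears on this change in a readable way, so no direction and no size can be drawn from the three values; the expectation rests only on the fact that every value so far is a limit. The step from compound 3 to compound 4 is therefore expected to be a step that the limit leaves unreadable from compound 3 to compound 4, which is no readable step at all. Compound 4 is estimated at 25000 nM, with a range from 8000 nM to 80000 nM, most likely reported again as a limit.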

Compound 4, half-maximal inhibitory concentration: > 20000 nM
Compound 4: no number, only a limit; the forecaster's own chance of this, stated with the estimate: 80%; the middle value is on the limit's open side.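

Compound 4 adds no readable step: its steps from compound 1, compound 2 and compound 3 all fall between two limits, so none can be read, and all four compounds sit at the same limit: the limit of > 20000 nM in this assay, at which 4 of the 4 values shown sit.

The compounds shown leave open whether any group on the shared core gives a measurable value in this assay.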